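The compounds below may be only part of what the source reports. "The series", "measured", "known", "first", "only" and "open" are said of these compounds alone.

Working notes on the series.

Compound 1 `CC(=O)c1c(NNc2ccccc2)cc(C)oc1=O` and compound 2 `CC(=O)c1c(NNc2ccc(C)cc2)cc(C)oc1=O` share one core; compound 3 `Cc1cc2nn(-c3ccccc3)c(C)c2c(=O)o1` is built on another, and the difference between the two cores is not broken down here. In a functional assay on the whole organism for inhibition, with Rattus norvegicus as the target, read by paw edema, with a stated time of 1 h, at a dose of 50 mg/kg (a lower number here means less inhibition, a higher number more inhibition at the dose given (going by the name of the read-out)), compound 1 gives 59.5%, compound 2 gives 60.1% and compound 3 gives 57%, so the three measured compounds sit within the usual scatter of one another and none is set apart.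

Among the compounds with values here, the one counted step in the set, a number 0.6 percentage points higher from compound 1 to compound 2 (within the scatter), belongs to the change (methyl in place of hydrogen on an aromatic carbon). Compound 4 `Cc1ccc(-n2nc3cc(C)oc(=O)c3c2C)cc1` has not yet been measured in this assay; it differs from compound 3 by methyl in place of hydrogen on an aromatic carbon, the same change in the same place on the ring, carried over from the first core to the second.

For compound 4 the step of a number 1 percentage points higher from compound 3 to compound 4 (within the scatter) is expected, resting on the flat step a number 0.6 percentage points higher from compound 1 to compound 2 (within the scatter) seen for the same change on the first core. On that basis compound 4 is estimated at 58% in this assay, with a range from 49% to 67%, which leaves it within scatter of compound 3.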

Compound 4, a percentage reported as inhibition, in the whole organism at one dose (the size of the read-out at that dose, not a potency): 63.3%
Estimate against measurement, compound 4: 5.3 percentage points below, within the range that was stated.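

In this assay, methyl in place of hydrogen on an aromatic carbon gives a number 6.3 percentage points higher from compound 3 to compound 4 (within the scatter), and the steps on the two cores do not differ: the same change on two cores in this assay, a number 0.6 percentage points higher (within the scatter) from compound 1 to compound 2 and a number 6.3 percentage points higher (within the scatter) from compound 3 to compound 4, 5.7 percentage points apart, within the scatter of two such steps. As far as these two pairs go, the change carries from the core of compound 1 to the core of compound 3 without a detectable difference in the size of the step. Neither step lies beyond the scatter, however, so this shows no effect of the methyl on either core, and two pairs at a single dose and a single time give no general rule for other cores.

Going by these compounds, only hydrogen and methyl appear at this place on the six-membered aromatic ring of carbon only, so it remains open whether chlorine, a methoxy group or a carboxylic acid there would give a step beyond the scatter. The methyl groups on the two cores also stay the same throughout, which leaves open what a longer chain in their place would do.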